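A few compounds are considered here, and "the series" means these few. Any claim that something is new, unique, unknown or untested is made for them only; others in the source may bear on it.

In an ADME assay for pharmacokinetics (on this read-out higher numbers stand for a longer-lived compound and lower numbers for a shorter-lived compound), compound 1 `C[C@H](NC(=O)OC(C)(C)C)C(=O)N[C@@H](C)C(=O)Nc1ccc2c(Cl)c(OCCSC(=N)N)oc(=O)c2c1` gives 0.667 h and compound 2 `CC(=O)Nc1ccc2c(Cl)c(OCCCSC(=N)N)oc(=O)c2c1` gives 1.13 h within the usual scatter of each other. Compound 3 `N=C(N)SCCCOc1oc(=O)c2cc(N)ccc2c1Cl` differs from compound 2 by one change (hydrogen in place of acetyl on a nitrogen on an aromatic ring), hydrogen in place of acetyl on a nitrogen on an aromatic ring. Among the measured compounds shown here, no measured pair covers this change, so no step beyond the scatter is expected. The expected step (a 1.3-fold lower number from compound 2 to compound 3 (0.10 log units; within the scatter)) is an estimate that rests on this lack of contrary data. The expected value for compound 3 is 0.9 h (estimated range 0.4 h to 2 h).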

Compound 3, half-life: 1.5 h
Compound 3: middle estimate off by 1.7-fold (0.22 log units), on the low side; measured number inside the range.
By their numbers in this assay, from the lowest: compounds 1, 2 and 3 (each within the scatter of the next, the first and the last beyond it).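

In this assay, among the compounds shown here, this is the first pair that differs in one place, acetamido to amino, and it reads a 1.3-fold higher number from compound 2 to compound 3 (0.12 log units; within the scatter). On a nitrogen on an aromatic ring, acetyl and hydrogen therefore cannot be told apart on this read-out. Nothing at hand explains this result. Going by these compounds, whether a larger acyl group, a sulfonamide or a carboxylic acid on that nitrogen would read the same remains open. Compound 1 and compound 2 differ in more than one place, so the effect of a longer chain cannot be judged from them.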